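This account rests on a few compounds, and the source may have more. Where it says the series, first, only, none or still open, it means among the compounds named here.

Going by the values given here, in a physicochemical assay for lipophilicity, using the shake flask method (on this read-out higher numbers stand for higher lipophilicity and lower numbers for lower lipophilicity), compound 1 `C[C@H](Oc1cc2cc(C(N)=O)ccc2nc1N)c1cc(F)c(F)cc1-n1cccn1` gives 3.2, the highest of the three numbers so far. Compound 3 `C[C@H](Oc1cc2cc(C(N)=O)ccc2nc1N)c1cc(F)ccc1-n1cccn1` gives 3, and the step of a number 0.20 log units lower from compound 1 to compound 3 (within the scatter) is hydrogen in place of fluoro on an aromatic carbon. Compound 2 `C[C@H](Oc1cc2cc(F)ccc2nc1N)c1cc(C(=O)O)ccc1-n1cccn1` sits far lower, at 0.9. Compound 4 `C[C@H](Oc1cc2cc(F)ccc2nc1N)c1cc(F)c(F)cc1-n1cccn1` differs from compound 1 by fluoro in place of carbamoyl on an aromatic carbon, which is fluoro in place of carbamoyl on an aromatic carbon. Among the compounds with values here, the one measured step leaves the carbamoyl untouched, so it gives no direct guide to this change. Compound 2 also differs from compound 1 in more than one place. From the structural change alone, a rise beyond the scatter is expected, and the estimated size is a number 1.00 log units higher from compound 1 to compound 4 (beyond the scatter). Compound 4 is therefore expected at 4.2, within a range of 3.6 to 4.8.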

Compound 4, distribution coefficient: 4.1
Beside the measured number, compound 4's estimate is 0.10 log units above it; the range from low to high includes it.
By their numbers in this assay, from the lowest: compound 2; then compounds 3 and 1 (each within the scatter of the next); then compound 4.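

In this assay the change from carbamoyl to fluoro gives a number 0.90 log units higher from compound 1 to compound 4 (beyond the scatter) and so shows that this position can move the read-out beyond the scatter, which the earlier step, made elsewhere on the molecule, did not. Nothing measured here explains the rise. The compounds shown leave open how a nitrile, a methoxy group or an amine would read at this same aromatic carbon. They also leave open whether the same swap gives a similar step starting from compound 3, which carries hydrogen in place of one fluoro.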